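A Second Methoxy Group and Its Expected Effect

The compounds below may be only part of what the source reports. "The series", "measured", "known", "first", "only" and "open" are said of these compounds alone.

Compound 1, `C=C(Br)C(=O)Nc1ccc(/C=C/C(=O)c2ccccc2)cc1`, gives 5000 nM in a functional assay on L1210 cells (Mus musculus) for antiproliferative activity, with a stated time of 48 h; a higher number here means a weaker inhibitor, a lower number a stronger inhibitor.
Compound 2, `C=C(Br)C(=O)Nc1ccc(/C=C/C(=O)c2cccc(OC)c2)cc1`, gives 2100 nM in this assay.
Compound 3, `C=C(Br)C(=O)Nc1ccc(C(=O)/C=C/c2ccccc2OC)cc1`, gives 1700 nM in this assay.

From compound 1 to compound 2 the change is methoxy in place of hydrogen on an aromatic carbon, and the step is a 2.4-fold lower number from compound 1 to compound 2 (0.38 log units; beyond the scatter). Compound 2 and compound 3 lie within the scatter of each other, while compound 1 stands beyond the scatter from compound 3. The difference between the core of compound 1 and the core of compound 3 is not broken down here.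

Compound 4, `C=C(Br)C(=O)Nc1ccc(C(=O)/C=C/c2ccc(OC)cc2OC)cc1`, is not yet measured. It differs from compound 3 by methoxy in place of hydrogen on an aromatic carbon. This is the same kind of change as that from compound 1 to compound 2, but the surroundings differ: in compound 2 the entering group stands meta to a large group, whereas in compound 4 it stands meta to a methoxy group and para to a large group. The step from compound 3 to compound 4 in this assay is expected to be a 1.7-fold lower number from compound 3 to compound 4 (0.23 log units; within the scatter), resting on a 2.4-fold lower number from compound 1 to compound 2 (0.38 log units; beyond the scatter) while allowing for the different surroundings. Compound 4 is estimated at 1000 nM, between 400 nM and 3500 nM.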

Compound 4, half-maximal inhibitory concentration: 520 nM
Estimate against measurement, compound 4: 1.9-fold (0.28 log units) above; the measured number falls inside the stated range.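

In this assay the methoxy change gives a 3.3-fold lower number from compound 3 to compound 4 (0.51 log units; beyond the scatter) on the core of compound 3, the same direction as on the core of compound 1. The two steps cannot be told apart in size, so within these two pairs the change carried from one core to the other: the same change on two cores in this assay, a 2.4-fold lower number (0.38 log units; beyond the scatter) from compound 1 to compound 2 and a 3.3-fold lower number (0.51 log units; beyond the scatter) from compound 3 to compound 4, 1.4-fold (0.14 log units) apart, within the scatter of two such steps. This does not show that the change would carry to a third core or to other places on the ring, and two pairs give no explanation for it.

The compounds shown leave open whether a hydroxyl, an ethoxy group or an amine in place of the entering methoxy would give a step of similar size. They also leave open what chlorine in place of the bromine would do.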